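Swapping an amide for a sulfonamide on a shared core

The compounds below may be only part of what the source reports. "The series", "measured", "known", "first", "only" and "open" are said of these compounds alone.

Four compounds share one core, carrying a nitrofuran amide on one side and a phenyl ring on the other. Compound 1 `O=C(Nc1nc(-c2ccccc2)cs1)c1ccc([N+](=O)[O-])o1` has the plain phenyl ring, and in an ADME assay on Vero cells (Chlorocebus sabaeus) for cytotoxicity, read by MTT assay, with a stated time of 72 h (a higher number here means a weaker inhibitor, a lower number a stronger inhibitor), compound 1 gives 41700 nM. Compound 2 `O=C(Nc1nc(-c2cccc(NC(=O)C3CCCCC3)c2)cs1)c1ccc([N+](=O)[O-])o1` adds a (cyclohexylcarbonyl)amino group to that ring; in this assay compound 2 gives 21900 nM, and the step of a 1.9-fold lower number from compound 1 to compound 2 (0.28 log units; within the scatter). On these data alone, compound 3 `COc1ccc(C(=O)Nc2cccc(-c3csc(NC(=O)c4ccc([N+](=O)[O-])o4)n3)c2)cc1` carries instead a ((4-methoxyphenyl)carbonyl)amino group at the same place; in this assay compound 3 gives "not determined" (no result reported), so its standing on this read-out is unknown.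

Compound 4 `CS(=O)(=O)Nc1cccc(-c2csc(NC(=O)c3ccc([N+](=O)[O-])o3)n2)c1` is the next step: methylsulfonyl in place of (4-methoxyphenyl)carbonyl on a nitrogen on an aromatic ring. For the measured compounds named here, the only measured step that bears on this position is the one from compound 1 to compound 2, where adding an acylamino group to the ring moved the number by an amount within the scatter. Going by the values given here, exchanging one such substituent for another at the same nitrogen is therefore expected to stay in the same territory, with no step in this assay beyond the scatter in either direction. For compound 4 the expected value in this assay is 30000 nM, with a plausible range from 12000 nM to 75000 nM.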

Compound 4, half-maximal inhibitory concentration: < 2820 nM
Compound 4: only a limit was reported (the forecaster's own chance of this, stated with the estimate: 15%); at least 10-fold (1.02 log units) between middle value and limit.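

For compound 4 the result in this assay is a limit and not a number: the limit of < 2820 nM in this assay, at which 1 of the 4 values shown sits. Even so, the limit is enough to show that this place on the ring is not indifferent to what it carries: against the plain phenyl ring, methanesulfonamido gives an at least 14-fold lower number from compound 1 to compound 4 (1.16 log units; beyond the scatter), whereas the earlier acylamino group gave only a 1.9-fold lower number from compound 1 to compound 2 (0.28 log units; within the scatter). The group on the nitrogen on the aromatic ring also matters, which compound 1 and compound 2 alone could not reveal, since methylsulfonyl in place of cyclohexylcarbonyl gives an at least 7.7-fold lower number from compound 2 to compound 4 (0.89 log units; beyond the scatter).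

On these data alone, the steps involving compound 3 cannot be read, as no result is reported for it, and how far compound 4 lies past its limit remains unknown, so the full size of both new steps stays open. As far as these compounds go, it is also open whether the sulfonyl link or the small methyl carries the change, a question that an ethylsulfonyl or longer chain, a phenylsulfonyl group, or a small acetyl group on the same nitrogen could help to settle.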